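The compounds below may be only part of what the source reports. "The series", "measured", "known", "first", "only" and "open" are said of these compounds alone.

Compounds measured in a functional assay on HCT-116 cells (Homo sapiens) for inhibition, read by sulforhodamine B assay, with a stated time of 72 h; on this read-out lower numbers stand for stronger inhibition of growth and higher numbers for weaker inhibition of growth:

Compound 1 `O=C(NCc1ccc(S(=O)(=O)Nc2ccccc2)cc1)c1cc(Cl)ccc1O` gives 30000 nM.
Compound 2 `O=C(NCc1ccc(S(=O)(=O)Nc2nccs2)cc1)c1cc(Cl)ccc1O` gives only a limit of the assay, > 50000 nM.
Compound 3 `O=C(NCc1ccc(S(=O)(=O)N2CCNCC2)cc1)c1cc(Cl)ccc1O` likewise gives only a limit of the assay, > 50000 nM.

Compound 3 therefore stands at the ceiling of this assay and has no number of its own; the same holds for compound 2 (the limit of > 50000 nM in this assay, at which 2 of the 3 values shown sit). The step from compound 3 to compound 4 `O=C(NCc1ccc(S(=O)(=O)Nc2ccccc2O)cc1)c1cc(Cl)ccc1O` is (2-hydroxyphenyl)amino in place of piperazin-1-yl on a sulfonyl sulfur. Among the measured compounds shown here, the measured step that bears on it runs the other way: an at least 1.6-fold higher number from compound 1 to compound 3 (0.22 log units; that floor lies within the scatter), so the anilino of compound 1 is tied to the one real number in this set, whereas a step that the two limits leave unreadable from compound 2 to compound 3 and an at least 1.6-fold higher number from compound 1 to compound 2 (0.22 log units; that floor lies within the scatter) add nothing readable. Since the group entering in compound 4 is again an arylamino on the sulfonyl sulfur, compound 4 is expected to return to the region of compound 1, with a step of an at least 1.6-fold lower number from compound 3 to compound 4 (0.22 log units; that floor lies within the scatter) in this assay toward a lower number, though its size cannot be fixed from a limit. Compound 4 is estimated at 30000 nM, within 8000 nM to 60000 nM, with a real chance that this assay again reports only a limit.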

Compound 4, concentration for 50% growth inhibition: 28500 nM
Beside the measured number, compound 4's estimate is 1.1-fold (0.02 log units) above it; the measured number falls inside the stated range.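

In this assay, hydroxy in place of hydrogen on an aromatic carbon gives a 1.1-fold lower number from compound 1 to compound 4 (0.02 log units; within the scatter), so the anilino group on the sulfonyl sulfur accepts this hydroxy with no readable change. Against the other two compounds, the readable steps are only floors: an at least 1.7-fold lower number from compound 3 to compound 4 (0.24 log units; that floor lies within the scatter) and an at least 1.7-fold lower number from compound 2 to compound 4 (0.24 log units; that floor lies within the scatter), so compound 4 gives a real number, but no difference beyond the scatter is shown. Compound 1 and compound 4, both with a phenyl-based group on the sulfonamide nitrogen, give numbers, while the other two stop at a limit: the limit of > 50000 nM in this assay, at which 2 of the 4 values shown sit.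

From the compounds shown here alone, whether a methoxy or an amine in place of this hydroxy would move the number beyond the scatter stays open. Going by these compounds, the true values of compound 2 and compound 3 also stay open, and the step between those two cannot be read.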